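A few compounds are considered here, and "the series" means these few. Any claim that something is new, unique, unknown or untested is made for them only; others in the source may bear on it.

Working notes on the series:
- compound 1 `Cc1ccc2[nH]c(-c3ccc(-c4ccc(-c5ccc(N(C)C)cc5)cc4)cc3)nc2c1`: 6240 nM
- compound 2 `FC(F)(F)c1ccc(-c2ccc(-c3ccc(-c4nc5ccccc5[nH]4)cc3)cc2)cc1`: 39100 nM

Both values come from a functional assay on Gurav cells (Homo sapiens) for inhibition, read by sulforhodamine B assay; on this read-out lower numbers stand for stronger inhibition of growth and higher numbers for weaker inhibition of growth. Of these two numbers, compound 2 has the higher at 39100 nM, and the gap to compound 1 at 6240 nM lies beyond the scatter.

The next compound to be read is compound 3 `COc1ccc(-c2ccc(-c3ccc(-c4nc5ccccc5[nH]4)cc3)cc2)cc1`. Relative to compound 2 the change is methoxy in place of trifluoromethyl on an aromatic carbon, para to a large group.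

Among the compounds with values here, no measured pair differs in one place only, so the size of this step has no direct precedent. Compound 1 at 6240 nM is the only lower reference, and it differs from compound 2 in more than one place. A moderate move towards lower numbers in this assay is expected, though it may stay close to the scatter.

The expected size is a 2.4-fold lower number from compound 2 to compound 3 (0.39 log units; beyond the scatter). For compound 3 the estimate is 16000 nM, with an expected range of 5000 nM to 50000 nM.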

Compound 3, concentration for 50% growth inhibition: 38100 nM
Estimate against measurement, compound 3: 2.4-fold (0.38 log units) below; the range from low to high includes it.
By their numbers in this assay, from the lowest: compound 1; then compounds 3 and 2 (each within the scatter of the next).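

In this assay, within the data shown here, methoxy in place of trifluoromethyl on an aromatic carbon, para to a large group, gives a 1.0-fold lower number from compound 2 to compound 3 (0.01 log units; within the scatter), the first step with a difference in one place only. At this place the two groups cannot be told apart on this read-out, even though 4 heavy atoms with 0 hydrogen-bond acceptors give way to 2 heavy atoms with 1 hydrogen-bond acceptor. No measurement bears on why this step is so small.

As far as these compounds go, whether any group at this place shifts the number in this assay stays open, for example a primary amine, a carboxylic acid or a longer alkoxy chain. Compound 1 differs from compound 2 and compound 3 in more than one place, so the contribution of each of its differences cannot be read from these compounds.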